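Moving the Chlorine Within the Ester Aryl Group

A few compounds are considered here, and "the series" means these few. Any claim that something is new, unique, unknown or untested is made for them only; others in the source may bear on it.

Compound 1 `COC(=O)c1cc(Cl)ccc1OC(=O)COc1cc(O)c2c(=O)cc(-c3ccccc3)oc2c1` is known in an ADME assay on cells (T-cell, Mus musculus, strain BALB/c) for cytotoxicity, read by MTT assay, with a stated time of 48 h (a lower number here means that less compound is tolerated, a higher number that more compound is tolerated), only as a limit: its value of > 436000 nM is the ceiling of the measurement, not a number, and the limit of > 436000 nM in this assay, at which 1 of the 3 values shown sits, shows that it alone of the three measured compounds sits there. Compound 2 `COC(=O)c1cc(O)ccc1OC(=O)COc1cc(O)c2c(=O)cc(-c3ccccc3)oc2c1` gives 263000 nM in this assay, and compound 3 `COC(=O)c1cccc(C)c1OC(=O)COc1cc(O)c2c(=O)cc(-c3ccccc3)oc2c1` gives 299000 nM. The two steps away from compound 1 are small and uncertain: an at least 1.6-fold lower number from compound 1 to compound 2 (0.21 log units; that floor lies within the scatter) and an at least 1.4-fold lower number from compound 1 to compound 3 (0.16 log units; that floor lies within the scatter), each only a floor that lies within the scatter. Between the two measured neighbours there is a 1.1-fold higher number from compound 2 to compound 3 (0.06 log units; within the scatter), also within the scatter.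

Compound 4 `COC(=O)c1c(Cl)cccc1OC(=O)COc1cc(O)c2c(=O)cc(-c3ccccc3)oc2c1` is yet to be measured. Its difference from compound 1 is 3-chloro-2-(methoxycarbonyl)phenyl in place of 4-chloro-2-(methoxycarbonyl)phenyl on an oxygen next to a carbonyl group. The two measured steps from compound 1 each alter the same aryl group on an oxygen next to a carbonyl group, and neither reached beyond the scatter, so a rearrangement of the same atoms within that group gives no ground to expect a step in either direction in this assay. Compound 4 is therefore expected to give about 400000 nM, between 200000 nM and 900000 nM, amounting to an at least 1.0-fold lower number from compound 1 to compound 4 (0.03 log units; that floor lies within the scatter), with a fair chance that this assay again reports only a limit.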

Compound 4, half-maximal cytotoxic concentration: 366000 nM
Compound 4: the middle estimate sits 1.1-fold (0.04 log units) above what was measured, and the stated range covers the measured number.
By their numbers in this assay, from the lowest: compounds 2, 3 and 4 (each within the scatter of the next). At a limit, above all of these: compound 1.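

For the compounds shown here, the chlorine-bearing ester aryl group now has a measured number in this assay, which the earlier compounds did not give, yet moving the chlorine still yields only a floor within the scatter: an at least 1.1-fold lower number from compound 1 to compound 4 (0.07 log units; that floor lies within the scatter). Set against the two other aryl groups with measured numbers, 3-chloro-2-(methoxycarbonyl)phenyl gives a 1.2-fold higher number from compound 3 to compound 4 (0.09 log units; within the scatter) and a 1.4-fold higher number from compound 2 to compound 4 (0.14 log units; within the scatter), so with the chlorine in this place, neither exchange reaches beyond the scatter. Compound 1 remains known only as a limit, which keeps the true size of the move out of reach: the limit of > 436000 nM in this assay, at which 1 of the 4 values shown sits.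

The compounds shown leave open whether a different kind of group on this aryl ring, such as an amine or a carboxylic acid in place of the chlorine, would give a step beyond the scatter in this assay. They also leave open whether a longer chain in place of the methyl of the methoxycarbonyl group would change the number, since every aryl group shown carries that same ester.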